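The source may report more compounds than this note shows. Statements on the series, on what has been measured and on what is new or still open speak of the compounds shown alone.

Working notes on the series. Within the data shown here, all three compounds measured so far share one core and differ only in one substituent on an aromatic carbon. In a functional assay on MCF7 cells (Homo sapiens) for antiproliferative activity (a higher number here means a weaker inhibitor, a lower number a stronger inhibitor), compound 2 (`CC(=O)Nc1ccc(-c2nc3ccccc3s2)cc1Cl`) gives > 10 nM, which is a limit and not a number. Compound 1 (`CC(=O)Nc1ccc(-c2nc3ccccc3s2)cc1C`) gives > 10000 nM, also a limit. Compound 3 (`CC(=O)Nc1ccc(-c2nc3ccccc3s2)cc1I`) gives > 100 nM, again a limit. Compound 2 therefore has no exact standing among the three.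

Compound 4 (`CC(=O)N(C(C)=O)c1ccc(-c2nc3ccccc3s2)cc1Cl`) carries acetyl in place of hydrogen on an amide-type nitrogen, acetamido to diacetylamino: acetyl in place of hydrogen on an amide-type nitrogen.

The measured changes are a step that the two limits leave unreadable from compound 1 to compound 2, a step that the two limits leave unreadable from compound 1 to compound 3 and a step that the two limits leave unreadable from compound 2 to compound 3. All three are exchanges on an aromatic carbon, so none touches the amide-type nitrogen, and none has a readable size. Among the measured compounds shown here, the series offers no measured precedent for this change.

The expectation therefore rests loosely on compound 2 with its limit of > 10 nM, and it stays wide. The estimated step is a step that the limit leaves unreadable from compound 2 to compound 4, expected toward weaker inhibition in this assay but with little confidence in its size. For compound 4 the expected value is 1000 nM, with an estimated range from 50 nM to 20000 nM.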

Compound 4, half-maximal inhibitory concentration: > 10000 nM
Compound 4 gave a limit, no number (the forecaster's own chance of this, stated with the estimate: 55%); middle value at least 10-fold (1.00 log units) from the limit.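

Compound 4 gives > 10000 nM, a limit and not a number. Among these compounds, compound 2 gives > 10 nM, also a limit, so no step in size can be read between compound 2 and compound 4. The compounds shown leave open whether acetyl in place of hydrogen on the amide-type nitrogen changes potency, and by how much.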